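The compounds below may be only part of what the source reports. "The series", "measured", "known", "first", "only" and "open" are said of these compounds alone.

Compound 1, `COc1cccc([C@@H](CO)O[C@H]2CCCN(Cc3ccc(C(=O)O)cc3C)[C@H]2c2ccccc2)c1`: 81000 nM
Compound 2, `O=C(O)C12CC(CN3CCC[C@H](O[C@H](CO)c4cc(Cl)cc(Cl)c4)[C@@H]3c3ccccc3)(C1)C2`: 12000 nM
Compound 3, `Cc1cc(C(=O)O)ccc1CN1CCC[C@H](O[C@H](CO)c2cc(Cl)cc(Cl)c2)[C@@H]1c1cccc(F)c1`: 12000 nM

All three were measured in an assay on isolated protein for activation of cGMP-dependent protein kinase 1 (Homo sapiens), read by ADP-Glo, with stated times of 30 min and 2 h, in the presence of a further agent that is not named here; a higher number here means that more compound is needed for the effect, a lower number that less compound is needed. Among them compound 1 stands at the highest number, with 81000 nM. Compound 2 gives 12000 nM and compound 3 gives 12000 nM, and both of those numbers lie below that of compound 1 by more than the usual scatter, so compound 1 is the one that needs the most compound for the effect.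

Compound 4, `Cc1cc(C(=O)O)ccc1CN1CCC[C@H](O[C@H](CF)c2cc(Cl)cc(Cl)c2)[C@@H]1c1ccccc1`, has not yet been measured. It differs from compound 1 in one place: a group of 11 heavy atoms (8 carbon, 1 fluorine, 2 chlorine; one six-membered aromatic ring of carbon only) in place of a group of 11 heavy atoms (9 carbon, 2 oxygen; one six-membered aromatic ring of carbon only), on an oxygen on a saturated carbon. Within the data shown here, no pair of measured compounds differs in exactly this way, so no measured step shows what this exchange does on its own. What can be said is that compound 2 and compound 3 both carry a six-membered aromatic ring with two chlorines, as compound 4 does, while they keep a hydroxyl that compound 4 lacks. On that basis a move to a lower number is expected for compound 4, of the size a 5.4-fold lower number from compound 1 to compound 4 (0.73 log units; beyond the scatter), which is beyond the scatter. The estimate for compound 4 is 15000 nM, with a range from 4000 nM to 60000 nM.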

Compound 4, half-maximal effective concentration: 9100 nM
Compound 4: middle estimate off by 1.6-fold (0.22 log units), on the high side; low and high end bracket the measured number.
By their numbers in this assay, from the lowest: compounds 4, 2 and 3 (each within the scatter of the next); then compound 1.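

In this assay, this position on an oxygen on a saturated carbon proves open to a real gain: exchanging the whole group gives an 8.9-fold lower number from compound 1 to compound 4 (0.95 log units; beyond the scatter). The group that enters has 0 hydrogen-bond donors and 0 hydrogen-bond acceptors, whereas the group that leaves has 1 donor and 2 acceptors, so within this single pair, neither the donor nor the acceptors of the leaving group are required for the lower number. Nothing measured here explains why the number falls, and no separate data on these groups accompany the result.

The exchange removes both oxygens and brings in the fluorine and both chlorines at once, leaving open how much of the step belongs to each atom, and a compound differing from compound 4 only by carrying one chlorine, or only by having a hydroxyl in place of the fluorine, would be needed to divide it. Also open is how this position responds to groups absent from the compounds shown, such as an amine, a nitrile or a longer chain.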